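The source may hold more compounds than are shown below. What is called first, only, known or untested is meant among the compounds shown, and "the series" means these compounds.

In a functional assay on A549 cells (Homo sapiens) for cytotoxicity, read by WST assay, with a stated time of 48 h (on this read-out lower numbers stand for stronger inhibition and higher numbers for weaker inhibition), compound 1 `COc1ccc2c(/C=C(\C#N)C(=O)c3c[nH]c4cc(F)ccc34)c[nH]c2c1` gives 5500 nM, and compound 2 `COc1ccc2[nH]cc(/C=C(\C#N)C(=O)c3c[nH]c4ccc(OC)cc34)c2c1` gives 24500 nM. Compound 3 `N#C/C(=C\c1cn(Cc2ccc(Cl)cc2)c2ccccc12)C(=O)c1c[nH]c2cc(F)ccc12` is recorded only as a limit, > 50000 nM, so it has no exact place on the scale. Compound 4 `N#C/C(=C\c1cn(Cc2ccc(Cl)cc2)c2ccccc12)C(=O)c1c[nH]c2ccccc12` differs from compound 3 by hydrogen in place of fluoro on an aromatic carbon, turning 6-fluoro-1H-indol-3-yl into 1H-indol-3-yl. Within the data shown here, no measured pair isolates this change. A small step toward stronger inhibition is expected, an at least 1.4-fold lower number from compound 3 to compound 4 (0.15 log units; that floor lies within the scatter), and it may stay within the scatter. For compound 4 the estimated value is 35000 nM, with an expected range of 10000 nM to 50000 nM, and another result reported only as a limit remains quite possible.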

Compound 4, half-maximal inhibitory concentration: > 50000 nM
Compound 4 ended at the assay's limit (the forecaster's own chance of this, stated with the estimate: 50%); middle value at least 1.4-fold (0.15 log units) from the limit.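

Compound 3 and compound 4 are both recorded only as limits, so no step can be read for hydrogen in place of fluoro on an aromatic carbon: the limit of > 50000 nM in this assay, at which 2 of the 4 values shown sit.

The compounds shown leave open what this change does where both partners have an exact value.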